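Swapping halogens on the benzyl arm of compound 1

A few compounds are considered here, and "the series" means these few. Any claim that something is new, unique, unknown or untested is made for them only; others in the source may bear on it.

Among the measured compounds shown here, compound 1 `CCCn1c(=O)c2nc(-c3cnn(Cc4cccc(Cl)c4)c3)[nH]c2n(CCC)c1=O` is the only compound with a full number in an in vitro assay on HEK293 cells for displacement of a labelled ligand from adenosine receptor A2b (Homo sapiens); on this read-out lower numbers stand for stronger inhibition and higher numbers for weaker inhibition: compound 1 gives 18 nM. Compound 2 `CCCn1c(=O)c2nc(-c3cnn(-c4ccc(Cl)cc4)c3C(F)(F)F)[nH]c2n(CCC)c1=O` returns in this assay no number but only a limit, namely > 6600 nM, and that is the limit of > 6600 nM in this assay, at which 1 of the 2 values shown sits. Compound 3 `CCCn1c(=O)c2nc(-c3cnn(Cc4cccc(F)c4F)c3)[nH]c2n(CCC)c1=O` differs from compound 1 by 2,3-difluorophenyl in place of 3-chlorophenyl on a saturated chain carbon bound to an aromatic nitrogen. For the measured compounds named here, no measured pair shows such a change, so the writer expects a step that stays within the usual scatter or leans slightly toward weaker binding. Compound 3 is estimated at 30 nM, with a range from 10 nM to 100 nM. The expected step of a 1.7-fold higher number from compound 1 to compound 3 (0.22 log units; within the scatter) is thus modest.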

Compound 3, inhibition constant: 240 nM
Beside the measured number, compound 3's estimate is 8.0-fold (0.90 log units) below it; the whole stated range lies below it.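

In this assay the step of a 13-fold higher number from compound 1 to compound 3 (1.12 log units; beyond the scatter) comes with 2,3-difluorophenyl in place of 3-chlorophenyl on a saturated chain carbon bound to an aromatic nitrogen, so this place on the benzyl arm does not accept every halogen pattern equally. Among the compounds shown here, it is the only single change measured here, and it lies beyond the scatter. Nothing measured here bears on why binding weakens.

The compounds shown leave open whether a single fluorine would behave like the two in compound 3. They also leave open how a bromine, a methoxy group or an amine would fare on this arm.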